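Nitro in Place of Acetamido on a Hydroxamate Growth Inhibitor

The compounds below may be only part of what the source reports. "The series", "measured", "known", "first", "only" and "open" are said of these compounds alone.

Measured so far:
compound 1 `O=C(CCC1=CCCN(CCCCc2ccc(-c3ccccc3)cc2)C1=O)NO`: 2950 nM
compound 3 `O=C(CCC1=CCCN(CCCc2ccc3ccccc3c2)C1=O)NO`: 300 nM
compound 2 `CC(=O)Nc1ccc(CN2CCC=C(CCC(=O)NO)C2=O)cc1`: > 10000 nM, a limit of the assay, not a number

In a functional assay on PC-3 cells (Homo sapiens) for inhibition, read by sulforhodamine B assay (a lower number here means a stronger inhibitor of growth, a higher number a weaker inhibitor of growth), compound 1 gives 2950 nM and compound 3 gives 300 nM. On these data alone, for compound 2 this assay reports only a limit, > 10000 nM, so compound 2 stands at the limit of > 10000 nM in this assay, at which 1 of the 3 values shown sits, and its true value is unknown beyond that. Compound 4 `O=C(CCC1=CCCN(Cc2ccc([N+](=O)[O-])cc2)C1=O)NO` is the next compound to be tested in this assay; it differs from compound 2 in nitro in place of acetamido on an aromatic carbon.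

Among the compounds with values here, no pair of measured compounds shows what this exchange does, so the expected step from compound 2 to compound 4 in this assay is a number no higher from compound 2 to compound 4 (the limit leaves the size open), none beyond the usual scatter. Compound 4 is therefore estimated at 10000 nM in this assay, between 3000 nM and 30000 nM, with a good chance that again only a limit is reported.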

Compound 4, concentration for 50% growth inhibition: 3010 nM
Compound 4: the middle estimate sits 3.3-fold (0.52 log units) above what was measured; the range from low to high includes it.
By their numbers in this assay, from the lowest: compound 3; then compounds 1 and 4 (each within the scatter of the next). At a limit, above all of these: compound 2.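

Exchanging acetamido for nitro, on an aromatic carbon para to a large group, changes growth inhibition at this position: in this assay there is an at least 3.3-fold lower number from compound 2 to compound 4 (0.52 log units; beyond the scatter). Within the data shown here, the earlier compounds held no exchange at this place, so this is the first sign that the group here matters. The true size of the step stays open, since compound 2 is only a limit of the assay: the limit of > 10000 nM in this assay, at which 1 of the 4 values shown sits.

A single exchange cannot separate what nitro adds from what acetamido takes away. An amine or a carboxylic acid at the same place would help to tell these apart.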